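Fluoro for Carbamoyl on the Benzyl Group of Compound 1

This account rests on a few compounds, and the source may have more. Where it says the series, first, only, none or still open, it means among the compounds named here.

Measured compounds:
compound 1, `NC(=O)c1cccc(Cn2cc(-c3ccc4cn[nH]c4c3)ccc2=O)c1`, 388 nM
compound 2, `Cn1ncc2ccc(-c3ccc(=O)n(Cc4ccccc4)c3)cc21`, > 2000 nM

Going by the values given here, compound 1 is the only compound with a numerical result in an assay for inhibition of MAP kinase-interacting serine/threonine-protein kinase 1 (Homo sapiens), read by luminescence and ADP-Glo, with a stated time of 2 h; a higher number here means a weaker inhibitor, a lower number a stronger inhibitor: compound 1 gives 388 nM. Compound 2 gives only a limit in this assay, > 2000 nM, which is the assay's boundary rather than a measured number; one of the two results sits at this boundary, (the limit of > 2000 nM in this assay, at which 1 of the 2 values shown sits). Among the compounds with values here, compound 2 differs from compound 1 in more than one place, so no single step between them can be read.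

Compound 3, `O=c1ccc(-c2ccc3cn[nH]c3c2)cn1Cc1cccc(F)c1`, has not yet been tested. It differs from compound 1 by fluoro in place of carbamoyl on an aromatic carbon. Within the data shown here, the carbamoyl that leaves is the only part of compound 1 that could donate and accept a hydrogen bond, and fluoro brings neither, so the step is expected to go toward weaker inhibition, clearly beyond the scatter, as a 3.9-fold higher number from compound 1 to compound 3 (0.59 log units; beyond the scatter). Compound 3 is expected to give about 1500 nM, most likely between 500 nM and 5000 nM.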

Compound 3, half-maximal inhibitory concentration: 74 nM
Compound 3: middle estimate off by 20-fold (1.31 log units), on the high side, and the stated range ends above it.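

In this assay, putting fluoro in place of carbamoyl gives a 5.2-fold lower number from compound 1 to compound 3 (0.72 log units; beyond the scatter), so the carbamoyl, with its hydrogen-bond donor and acceptor, is not needed at this aromatic carbon for inhibition. Going by these compounds alone, a single fluoro, which brings neither a donor nor an acceptor, does better here than the larger group it replaces, something the earlier compounds could not show with no readable step between them. No measurement shown explains why the number falls.

Compound 2 gives only a limit, > 2000 nM, and it differs from compound 1 in more than one place, so that step cannot be read. As far as these compounds go, it remains open whether fluoro itself helps or the gain comes only from losing the carbamoyl, a question that a plain hydrogen, chloro, or an amine on the same carbon could help to separate.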